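Vinyl to prop-1-en-1-yl on the acrylamide of two cores

The compounds below may be only part of what the source reports. "The series", "measured", "known", "first", "only" and "open" are said of these compounds alone.

Measured so far:
compound 1 `C=CC(=O)Nc1ccc(Cn2nc(-c3ccc(Oc4ccccc4)cc3)cc2C(=O)O)cc1` — > 60000 nM
compound 2 `C/C=C/C(=O)Nc1ccc(Cn2nc(-c3ccc(Oc4ccccc4)cc3)cc2C(=O)O)cc1` — > 60000 nM
compound 3 `C=CC(=O)N1CCCC(n2nc(-c3ccc(Oc4ccccc4)cc3)cc2C(=O)O)C1` — > 60000 nM

In a functional assay on Z-138 cells (Homo sapiens) for inhibition, read by luminescence and CellTiter-Glo, with a stated time of 72 h (on this read-out lower numbers stand for stronger inhibition and higher numbers for weaker inhibition), compound 1 gives only a limit, > 60000 nM. Compound 2 likewise gives only a limit in this assay, > 60000 nM. Compound 3 also gives only a limit, > 60000 nM. The change from compound 1 to compound 2 is prop-1-en-1-yl in place of vinyl on a carbonyl carbon, and its step, a step that the two limits leave unreadable from compound 1 to compound 2, cannot be read because of the limit of > 60000 nM in this assay, at which 3 of the 3 values shown sit. The difference between the cores of compound 1 and compound 3 is not broken down here.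

Compound 4 `C/C=C/C(=O)N1CCCC(n2nc(-c3ccc(Oc4ccccc4)cc3)cc2C(=O)O)C1` is not yet measured. Its change from compound 3 is prop-1-en-1-yl in place of vinyl on a carbonyl carbon, the same kind of change as from compound 1 to compound 2; the place differs in that the amide-type nitrogen is in a ring. Since compound 3 sits at the limit > 60000 nM and the earlier step is unreadable, compound 4 is expected to remain at the limit, a step of about a number no higher from compound 3 to compound 4 (the limit leaves the size open), with an estimate of 60000 nM.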

Compound 4, half-maximal inhibitory concentration: > 60000 nM
Compound 4: no number, only a limit; the forecaster's own chance of this, stated with the estimate: 85%; the middle value sits exactly at the limit.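

No step can be read from compound 3 to compound 4, because both values are limits: the limit of > 60000 nM in this assay, at which 4 of the 4 values shown sit.

The compounds shown leave open whether prop-1-en-1-yl in place of vinyl, or the difference between the cores, changes inhibition at all.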